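The compounds below may be only part of what the source reports. "The series", "measured", "known", "first", "only" and "open" are said of these compounds alone.

The shared core of compound 1 `Cc1cccc(C(=O)n2c(-c3cn(-c4ccccc4)nc3-c3ccc(C(F)(F)F)cc3)nc3ccccc32)c1`, compound 2 `O=C(c1ccncc1)n1c(-c2cn(-c3ccccc3)nc2-c2ccc(F)cc2)nc2ccccc21` and compound 3 `Cc1ccc(-c2nn(-c3ccccc3)cc2-c2nc3ccccc3n2C(=O)c2ccccc2)cc1` was tested in an ADME assay on HEK-293T cells (Homo sapiens) for cytotoxicity, read by MTT assay, with a stated time of 24 h; on this read-out higher numbers stand for lower toxicity in this test and lower numbers for higher toxicity in this test. In this assay compound 1 gives 154000 nM, compound 2 gives 151000 nM and compound 3 gives 204000 nM; the three numbers lie within the usual scatter of one another, so none of these compounds can be called more or less toxic than the others. Compound 4 `Cc1ccc(C(=O)n2c(-c3cn(-c4ccccc4)nc3-c3ccc(C(F)(F)F)cc3)nc3ccccc32)cn1` has not been measured yet. It differs from compound 1 in one place: 6-methylpyridin-3-yl in place of 3-methylphenyl on a carbonyl carbon. Since the three measured compounds sit close together, the step from compound 1 to compound 4 is expected to be small, a 1.0-fold higher number from compound 1 to compound 4 (0.02 log units; within the scatter), with no clear direction beyond the scatter. Compound 4 is therefore estimated at 160000 nM, between 90000 nM and 280000 nM.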

Compound 4, half-maximal cytotoxic concentration: 153000 nM
The estimate for compound 4 lay 1.0-fold (0.02 log units) above the measured number, and the stated range covers the measured number.
By their numbers in this assay, from the lowest: compounds 2, 4, 1 and 3 (each within the scatter of the next).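

Replacing 3-methylphenyl with 6-methylpyridin-3-yl on a carbonyl carbon puts a nitrogen into the ring and adds a hydrogen-bond acceptor, yet in this assay the change (a 1.0-fold lower number from compound 1 to compound 4 (0.00 log units; within the scatter)) stays within the scatter. This is the first pair shown that differs in one place, so this swap can now be read directly rather than inferred from compounds that differ in several places. No measurement at hand offers an explanation for this result. Still open, as far as these compounds go, is whether a different group at this place, such as an amine or a carboxylic acid, would shift the number beyond the scatter.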